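Carbonyl substituent variation on the piperidine carbamate/amide series

This account rests on a few compounds, and the source may have more. Where it says the series, first, only, none or still open, it means among the compounds named here.

Three compounds share one core and differ only at the carbonyl carbon. In a functional assay on isolated protein for inhibition of Glucose-dependent insulinotropic receptor (Rattus norvegicus), read by HTRF and cAMP accumulation (on this read-out lower numbers stand for an effect already at smaller amounts and higher numbers for an effect only at larger amounts of compound), compound 1 `Cc1nc(S(C)(=O)=O)ccc1Oc1ncnc(OC2CCN(C(=O)OC(C)(C)C(F)(F)F)CC2)c1F` gives 47.2 nM, compound 2 `Cc1nc(S(C)(=O)=O)ccc1Oc1ncnc(OC2CCN(C(=O)O[C@@H](C)CF)CC2)c1F` gives 1680 nM, and compound 3 `Cc1nc(S(C)(=O)=O)ccc1Oc1ncnc(OC2CCN(C(=O)C(C)(F)F)CC2)c1F` gives 239 nM. Compound 3 thus stands second highest of the three: the change a 5.1-fold higher number from compound 1 to compound 3 (0.70 log units; beyond the scatter) was modest, while a 7.0-fold lower number from compound 2 to compound 3 (0.85 log units; beyond the scatter) was also modest, and a 36-fold higher number from compound 1 to compound 2 (1.55 log units; beyond the scatter) was large. Compound 4 `CCc1cnc(C(=O)N2CCC(Oc3ncnc(Oc4ccc(S(C)(=O)=O)nc4C)c3F)CC2)nc1` carries 5-ethylpyrimidin-2-yl in place of 1,1-difluoroethyl on a carbonyl carbon. For the measured compounds named here, no measured step introduces a ring at this position, so the bearing of the measured steps is indirect; they show only that substituent changes on this carbonyl carbon move this assay by modest to large amounts in either direction. For compound 4 a modest step toward a lower number is expected, a 1.8-fold lower number from compound 3 to compound 4 (0.26 log units; within the scatter), with the direction held loosely given the lack of a direct precedent. The estimate for compound 4 in this assay is 130 nM, within a range of 25 nM to 700 nM.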

Compound 4, half-maximal effective concentration: 40.8 nM
The estimate for compound 4 lay 3.2-fold (0.50 log units) above the measured number; the measured number falls inside the stated range.
By their numbers in this assay, from the lowest: compounds 4 and 1 (each within the scatter of the next); then compound 3; then compound 2.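

The 5-ethylpyrimidin-2-yl group is the first ring shown on this carbonyl carbon, and a 5.9-fold lower number from compound 3 to compound 4 (0.77 log units; beyond the scatter) in this assay shows that an aromatic ring is accepted here and can replace 1,1-difluoroethyl with a gain. The gap to the fluoromethyl carbamate is larger, with a 41-fold lower number from compound 2 to compound 4 (1.61 log units; beyond the scatter) on the same read-out. Fluorine in this substituent is not required for a low number: a 1.2-fold lower number from compound 1 to compound 4 (0.06 log units; within the scatter) puts the ring-bearing amide level with the 1-methyl-1-(trifluoromethyl)ethoxy carbamate, the two lying within the scatter.

Open, on these data alone, is the part played by the ethyl group, which a plain pyrimidin-2-yl, a methyl or a longer propyl chain would address, and whether a phenyl or pyridin-2-yl ring behaves like the pyrimidine. Nothing available explains why this ring lowers the number.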